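The source may hold more compounds than are shown below. What is called first, only, known or untested is meant among the compounds shown, and "the series" means these compounds.

Measured compounds in an assay on HEK293 cells for displacement of a labelled ligand from Sigma non-opioid intracellular receptor 1 (Homo sapiens), read by scintillation counting, with a stated time of 120 min; a lower number here means a stronger inhibitor, a higher number a weaker inhibitor:
compound 1 `N#Cc1ccc(-c2ncnc3c2cnn3CCN2CCCCC2)cc1`: 558 nM
compound 2 `Fc1ccc(-c2ncnc3c2cnn3CCN2CCCCC2)c(F)c1`: 93 nM
compound 3 `Cc1cc(F)ccc1-c1ncnc2c1cnn2CCN1CCCCC1`: 48 nM

Compound 3 gives the lowest number of the three, but the step of a 1.9-fold lower number from compound 2 to compound 3 (0.29 log units; within the scatter) lies within the scatter, so compound 2 and compound 3 cannot be ranked against each other; only compound 1 stands clearly apart, the gap being a 12-fold lower number from compound 1 to compound 3 (1.07 log units; beyond the scatter). Compound 4 `Cn1nccc1-c1ncnc2c1cnn2CCN1CCCCC1` is not yet measured. Its change from compound 3: 1-methyl-1H-pyrazol-5-yl in place of 4-fluoro-2-methylphenyl on an aromatic carbon. Within the data shown here, the steps that bear on it, a 6.0-fold lower number from compound 1 to compound 2 (0.78 log units; beyond the scatter) and a 12-fold lower number from compound 1 to compound 3 (1.07 log units; beyond the scatter), show that the group on this aromatic carbon moves the numbers a good deal, and compound 1, the one measured group carrying a hydrogen-bond acceptor, gave the highest number with 558 nM. A step towards weaker inhibition is therefore expected, a 4.2-fold higher number from compound 3 to compound 4 (0.62 log units; beyond the scatter). Compound 4 is estimated at 200 nM, with a range of 60 nM to 700 nM.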

Compound 4, inhibition constant: 41 nM
Estimate against measurement, compound 4: 4.9-fold (0.69 log units) above; the whole stated range lies above it.
By their numbers in this assay, from the lowest: compounds 4, 3 and 2 (each within the scatter of the next, the first and the last beyond it); then compound 1.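

In this assay, 1-methyl-1H-pyrazol-5-yl, a five-membered aromatic ring with 2 hetero atoms, matches 4-fluoro-2-methylphenyl at this position (a 1.2-fold lower number from compound 3 to compound 4 (0.07 log units; within the scatter)), and the gaps to the other groups lie beyond the scatter (a 2.3-fold lower number from compound 2 to compound 4 (0.36 log units; beyond the scatter); a 14-fold lower number from compound 1 to compound 4 (1.13 log units; beyond the scatter)). Hydrogen-bond acceptors on this group therefore do not by themselves go with a high number: compound 4 carries them, yet compound 1 alone stands high. No measurement available here accounts for these steps. Open, on these data alone, is whether the pyrazole keeps this level without its methyl. Also open, as far as these compounds go, is how a pyridin-3-yl ring or a simple amine would fare on this aromatic carbon.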